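The source may report more compounds than this note shows. Statements on the series, on what has been measured and on what is new or still open speak of the compounds shown alone.

Working notes on the series. In a functional assay on K562 cells (Homo sapiens) for cytotoxicity, read by MTT assay, with a stated time of 48 h (on this read-out higher numbers stand for weaker inhibition and lower numbers for stronger inhibition), compound 1 `COc1ccc(-c2c[nH]c(=O)n2-c2cc(OC)c(OC)c(OC)c2)cc1OC` has the entry "not determined" (no result reported), so it offers no result. Compound 2 `COc1ccc(-c2cn(C(=O)Nc3cc(OC)c(OC)c(OC)c3)c(=O)n2-c2cc(OC)c(OC)c(OC)c2)cc1OC` reads > 50000 nM, which is a limit of the assay and not a number. Compound 3 `COc1cc(-n2c(-c3ccc(Cl)cc3)cn(C(C)=O)c2=O)cc(OC)c1OC` reads > 50000 nM, which is likewise a limit. Compound 4 `COc1ccc(-c2cn(C(C)=O)c(=O)n2-c2cc(OC)c(OC)c(OC)c2)cc1N` carries 3-amino-4-methoxyphenyl in place of the 4-chlorophenyl of compound 3, on an aromatic carbon of the shared core: 3-amino-4-methoxyphenyl in place of 4-chlorophenyl on an aromatic carbon. Within the data shown here, no measured step links any two compounds, so the expectation for this assay has no direct guide. The estimated step of an at least 25-fold lower number from compound 3 to compound 4 (1.39 log units; beyond the scatter) runs toward stronger inhibition, with wide uncertainty. For compound 4 the expected value is 2000 nM, with an estimated range of 50 nM to 50000 nM.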

Compound 4, half-maximal inhibitory concentration: 500 nM
Compound 4: the middle estimate sits 4.0-fold (0.60 log units) above what was measured; the range from low to high includes it.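

3-amino-4-methoxyphenyl in place of 4-chlorophenyl on this aromatic carbon gives an at least 100-fold lower number from compound 3 to compound 4 (2.00 log units; beyond the scatter) in this assay and the only numeric reading among the compounds shown. This position therefore responds strongly to the aryl group it carries, with the acetyl group held constant. The size of the step is bounded on one side only, as compound 3 sits at a limit: the limit of > 50000 nM in this assay, at which 2 of the 4 values shown sit.

Still open, going by these compounds, is whether the amine or the methoxy group alone would carry the step. Also open, on these data alone, is how a hydroxyl or dimethylamino group there would read.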